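Same atoms, joined differently: compound 3 to compound 4

The source may report more compounds than this note shows. Statements on the series, on what has been measured and on what is new or still open speak of the compounds shown alone.

Measured in a functional assay on MCF7 cells (Homo sapiens) for antiproliferative activity, read by MTT assay, with a stated time of 72 h; on this read-out lower numbers stand for stronger inhibition and higher numbers for weaker inhibition:
- Compound 1 `CC(C)=CC(=O)Nc1cccc(Oc2nc(Nc3ccn(C)n3)nc3c2CSCC3)c1`: > 50000 nM (a limit, not a number)
- Compound 2 `C=CC(=O)Nc1cccc(Oc2nc(Nc3cccc(OC)c3)nc3c2CSCC3)c1`: > 50000 nM (a limit, not a number)
- Compound 3 `CC/C=C/C(=O)Nc1cccc(Oc2nc(Nc3cccc(OC)c3)nc3c2CSCC3)c1`: 24200 nM

Compound 3 is the only one of the three with an actual number, while the other two sit at the limit of > 50000 nM in this assay, at which 2 of the 3 values shown sit. The next compound to consider is compound 4 `COc1cccc(Nc2nc3c(c(Oc4cccc(NC(=O)C=C(C)C)c4)n2)CSCC3)c1`, and the change is 2-methylprop-1-en-1-yl in place of but-1-en-1-yl on a carbonyl carbon. Put simply, 2-methylprop-1-en-1-yl takes the place of but-1-en-1-yl on a carbonyl carbon.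

Within the data shown here, one measured step bears on this group: an at least 2.0-fold lower number from compound 2 to compound 3 (0.31 log units; beyond the scatter). Among the measured compounds shown here, that step starts from a limit and involves a different swap, so it shows only that this group can matter here. Compound 1 also carries 2-methylprop-1-en-1-yl on a carbonyl carbon but differs elsewhere, and its > 50000 nM is a limit. Compound 4 could therefore also end at a limit.

No step beyond the scatter is expected in this assay, and the estimated change is a 1.2-fold higher number from compound 3 to compound 4 (0.09 log units; within the scatter). For compound 4 the expected value is 30000 nM, with an estimated range of 13000 nM to 60000 nM.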

Compound 4, half-maximal inhibitory concentration: > 50000 nM
Compound 4 was reported as a limit; the forecaster's own chance of this, stated with the estimate: 35%; middle value at least 1.6-fold (0.22 log units) away from the limit.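

In this assay, replacing but-1-en-1-yl with 2-methylprop-1-en-1-yl on the carbonyl carbon gives an at least 2.0-fold higher number from compound 3 to compound 4 (0.31 log units; beyond the scatter). Among these compounds, the group that leaves and the group that enters hold the same atoms, so at this position the way those atoms are joined matters, and not only which atoms are present; the one earlier readable step, an at least 2.0-fold lower number from compound 2 to compound 3 (0.31 log units; beyond the scatter), could not show this because vinyl and but-1-en-1-yl differ in atom count. The result for compound 4 is a limit and not a number, and it sits with most of the series: the limit of > 50000 nM in this assay, at which 3 of the 4 values shown sit.

The steps to compound 4 from compound 1 and compound 2 join two limits and cannot be read. On these data alone, whether a longer chain or an amine at this position would give a lower number than compound 3, at 24200 nM, stays open.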